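A few compounds are considered here, and "the series" means these few. Any claim that something is new, unique, unknown or untested is made for them only; others in the source may bear on it.

Measured so far:
- compound 1, `CNS(=O)(=O)c1cncc(-c2ccn3nc(N)nc3c2)c1`: 39800000 nM
- compound 2, `CC(C)NS(=O)(=O)c1cncc(-c2ccn3nc(N)nc3c2)c1`: 63100000 nM

In an assay on isolated protein for inhibition of phosphatidylinositol 4,5-bisphosphate 3-kinase catalytic subunit beta isoform (Homo sapiens) (on this read-out higher numbers stand for weaker inhibition and lower numbers for stronger inhibition), compound 1 gives 39800000 nM, and compound 2 gives 63100000 nM. Going by the values given here, compound 2 has the higher of the two numbers, but the only step that joins them, a 1.6-fold higher number from compound 1 to compound 2 (0.20 log units; within the scatter), is within the scatter, so the two compounds cannot be told apart on this read-out.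

Compound 3, `Nc1nc2cc(-c3cncc(S(N)(=O)=O)c3)ccn2n1`, has not yet been measured. It differs from compound 2 by hydrogen in place of isopropyl on a sulfonamide nitrogen. Among the compounds with values here, the one step seen so far at this same sulfonamide nitrogen, a 1.6-fold higher number from compound 1 to compound 2 (0.20 log units; within the scatter), swapped one small alkyl group for another and produced no change beyond the scatter. Removing the alkyl group altogether is a step of a different kind, and nothing measured shows its effect. Within the data shown here, with only that within-scatter step to go on, no change beyond the scatter is expected for compound 3, as a 1.6-fold lower number from compound 2 to compound 3 (0.20 log units; within the scatter). Compound 3 is therefore estimated at 40000000 nM, within a range from 12000000 nM to 130000000 nM.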

Compound 3, half-maximal inhibitory concentration: 39800000 nM
Beside the measured number, compound 3's estimate is 1.0-fold (0.00 log units) above it; the measured number falls inside the stated range.
By their numbers in this assay, from the lowest: compounds 1, 3 and 2 (each within the scatter of the next).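

Taking the isopropyl off the sulfonamide nitrogen gives a 1.6-fold lower number from compound 2 to compound 3 (0.20 log units; within the scatter) and taking the methyl off gives no change at the digits printed from compound 1 to compound 3 (within the scatter) in this assay so the bare sulfamoyl cannot be told apart from either alkylated form. Going by these compounds alone, the earlier compounds compared only one small alkyl group with another, whereas these steps show that on this read-out, the alkyl group can be removed entirely with no change beyond the scatter. No supporting measurement is available to explain this result.

Still open, from the compounds shown here alone, is whether a longer chain on this nitrogen, or a group carrying an amine or a carboxylic acid, would move the number beyond the scatter. Also open, going by these compounds, is whether an amide in place of the sulfonamide would change the number.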